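Methylurea in Place of Pyrrole Amide on a Tetralin Sulfone

The compounds below may be only part of what the source reports. "The series", "measured", "known", "first", "only" and "open" are said of these compounds alone.

Measured compounds:
compound 1 `CNC[C@@H]1CCCc2cc(S(=O)(=O)c3cc[nH]c3)ccc21` 0.159 nM
compound 2 `O=C(NC[C@@H]1CCCc2cc(S(=O)(=O)c3cccc(F)c3)ccc21)c1ccc[nH]1` 5.01 nM

Of the compounds shown here, two have been measured in an assay on isolated protein for displacement of a labelled ligand from 5-hydroxytryptamine receptor 6 (Homo sapiens); a lower number here means a stronger inhibitor, a higher number a weaker inhibitor. Compound 1 gives 0.159 nM, while compound 2 gives 5.01 nM, the higher of the two numbers, with a gap beyond the scatter. These two differ in more than one place, so the numbers alone are what they show.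

Compound 3 `CNC(=O)NC[C@@H]1CCCc2cc(S(=O)(=O)c3cccc(F)c3)ccc21` is not yet measured. It differs from compound 2 in one place: methylamino in place of 1H-pyrrol-2-yl on a carbonyl carbon. Nothing measured tracks this change, so any expectation rests on compound 2 alone. Since compound 2 gives 5.01 nM, compound 3 is expected to sit close to that, with a step of a 1.6-fold higher number from compound 2 to compound 3 (0.20 log units; within the scatter) that may well fall within the scatter. Compound 3 is therefore estimated at 8 nM, with a range from 2 nM to 40 nM.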

Compound 3, inhibition constant: 0.398 nM
Beside the measured number, compound 3's estimate is 20-fold (1.30 log units) above it; the whole stated range lies above it.
By their numbers in this assay, from the lowest: compound 1; then compound 3; then compound 2.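

On a carbonyl carbon whose other neighbour is an amide-type nitrogen, replacing 1H-pyrrol-2-yl with methylamino gives a 13-fold lower number from compound 2 to compound 3 (1.10 log units; beyond the scatter) in this assay, so what sits at this position matters to the number. The five-membered aromatic ring is not required for a low number here, since methylamino has no ring and fewer heavy atoms, and compound 3 still gives the lower number; each group counts one hydrogen-bond donor, so that count does not separate the two compounds. No measurement here explains the size of this step.

As far as these compounds go, it remains open how ethylamino, dimethylamino or methoxy on the same carbonyl carbon would compare with methylamino. From the compounds shown here alone, it is also open whether the same change would give a step of similar size in compounds carrying a different group on the sulfone.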